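Acetyl to propanoyl: a small expected step

The source may hold more compounds than are shown below. What is called first, only, known or untested is meant among the compounds shown, and "the series" means these compounds.

Going by the values given here, in a physicochemical assay for solubility, in phosphate buffer, with a stated time of 24 h, at pH 7.4, tested at 100 uM (on this read-out lower numbers stand for lower solubility and higher numbers for higher solubility), compound 2 (`CC(=O)N1CCC(S(=O)(=O)c2ccc(CNC(=O)N3Cc4ccncc4C3)cc2)CC1`) gives 187000 nM, the higher of the two numbers so far. In this assay compound 1 (`O=C(NCc1ccc(S(=O)(=O)c2cccc(C(F)(F)F)c2)cc1)N1Cc2ccncc2C1`) gives 10000 nM. Among the compounds with values here, the one measured step, a 19-fold higher number from compound 1 to compound 2 (1.27 log units; beyond the scatter), is large and puts 1-acetylpiperidin-4-yl in place of 3-(trifluoromethyl)phenyl on a sulfonyl sulfur.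

Compound 3 (`CCC(=O)N1CCC(S(=O)(=O)c2ccc(CNC(=O)N3Cc4ccncc4C3)cc2)CC1`) differs from compound 2 by methyl in place of hydrogen on a saturated chain carbon bound to a carbonyl carbon, which turns acetyl into propanoyl. Within the data shown here, no measured pair tests this change directly. Among the measured compounds shown here, the one measured step exchanges a whole group, so it gives only a loose guide and no measure of a change this small. The estimate therefore starts from compound 2 at 187000 nM. No step beyond the scatter is expected, with a slightly lower number as the likelier direction. The expected step is a 1.2-fold lower number from compound 2 to compound 3 (0.10 log units; within the scatter). Compound 3 is expected at 150000 nM, with an estimated range of 80000 nM to 260000 nM.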

Compound 3, solubility: 216000 nM
The estimate for compound 3 lay 1.4-fold (0.16 log units) below the measured number, within the range that was stated.
By their numbers in this assay, from the lowest: compound 1; then compounds 2 and 3 (each within the scatter of the next).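

In this assay, methyl in place of hydrogen on a saturated chain carbon bound to a carbonyl carbon gives a 1.2-fold higher number from compound 2 to compound 3 (0.06 log units; within the scatter), so acetyl and propanoyl cannot be told apart on this read-out, a comparison that compounds 1 and 2 alone could not offer. The large step from the aryl sulfone also holds with the propanoyl group, at a 22-fold higher number from compound 1 to compound 3 (1.33 log units; beyond the scatter), and it now stands beside a 19-fold higher number from compound 1 to compound 2 (1.27 log units; beyond the scatter) as a second large step of the same direction, each exchanging 3-(trifluoromethyl)phenyl on a sulfonyl sulfur for an acylated piperidine. No evidence is available that bears on the origin of these readings.

Going by these compounds, whether the flat reading at this position continues with a longer chain such as butanoyl, a branched chain such as 2-methylpropanoyl, an amine or a carboxylic acid remains open. Also open, on these data alone, is how much of the large step rests on the acyl group and how much on the remainder of the substituent, a question that a free piperidin-4-yl amine on the sulfonyl sulfur would address.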